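The compounds below may be only part of what the source reports. "The series", "measured", "known", "first", "only" and "open" are said of these compounds alone.

Working notes on the series, read in a functional assay on MCF7 cells (Homo sapiens) for inhibition, read by MTT assay, with a stated time of 72 h; on this read-out lower numbers stand for stronger inhibition and higher numbers for weaker inhibition. Compound 1 `Cc1cc(Nc2ccn(Cc3cccc4ccccc34)n2)n2nc(SCc3ccc(Br)cc3)nc2n1` gives 4310 nM. Compound 2 `Cc1cc(Nc2ccn(Cc3ccccc3)n2)n2nc(SCc3ccc(Br)cc3)nc2n1` gives 15800 nM. Compound 3 `Cc1cc(Nc2cc(-c3ccccc3)[nH]n2)n2nc(SCC3CCCCC3)nc2n1` stands at > 50000 nM, which is a limit of the assay and not a number.

Compound 4 `C#CCSc1nc2nc(C)cc(Nc3cc(-c4ccccc4)[nH]n3)n2n1` departs from compound 3 by ethynyl in place of cyclohexyl on a saturated chain carbon bound to a sulfur. In words, this is ethynyl in place of cyclohexyl on a saturated chain carbon bound to a sulfur, or cyclohexylmethyl to propargyl when cut one bond further out.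

Going by the values given here, no measured step covers this change. Among the compounds with values here, the only sized step is a 3.7-fold higher number from compound 1 to compound 2 (0.56 log units; beyond the scatter). It sits at another place, on a saturated chain carbon bound to an aromatic nitrogen, and on compounds that also differ from compound 3 elsewhere, so it offers a rough scale and no more. Compound 3 carries no number, so the direction cannot be read from the data. Only a move to a lower number could show up as a step, and a result that again reaches the limit is just as plausible. A modest step at most is expected in this assay.

The estimated move is an at least 1.6-fold lower number from compound 3 to compound 4 (0.22 log units; that floor lies within the scatter). Compound 4 is expected at about 30000 nM, with an estimated range of 10000 nM to 80000 nM.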

Compound 4, half-maximal inhibitory concentration: 21800 nM
Compound 4: the middle estimate sits 1.4-fold (0.14 log units) above what was measured; low and high end bracket the measured number.
By their numbers in this assay, from the lowest: compound 1; then compounds 2 and 4 (each within the scatter of the next). At a limit, above all of these: compound 3.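

In this assay, replacing cyclohexylmethyl with propargyl gives an at least 2.2-fold lower number from compound 3 to compound 4 (0.36 log units; beyond the scatter), which shows that the group on a saturated chain carbon bound to a sulfur can move the read-out beyond the scatter. Going by these compounds alone, the only sized step among the earlier compounds sat at another place, on a saturated chain carbon bound to an aromatic nitrogen, so this is the first sized step at the sulfur side of the series, and compound 4 gives the first number for the amine side it shares with compound 3. Compound 3 remains at a limit of the assay and not at a number, so the step is only a floor and its full size stays unknown: the limit of > 50000 nM in this assay, at which 1 of the 4 values shown sits.

The pair changes the ring and the triple bond together, so the compounds shown leave open which of the two carries the step, a question that a propyl chain at the same place could help to settle. Also open, on these data alone, is how a carboxylic acid or an amine at the end of that chain would read, and whether the size of the step would hold on the core of compound 1.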